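A few compounds are considered here, and "the series" means these few. Any claim that something is new, unique, unknown or untested is made for them only; others in the source may bear on it.

- compound 1 `CCCCn1cc(C(=O)O)c(=O)c2cc(F)c(Cl)cc21` gives > 100000 nM in an ADME assay on J774.1 cells (Mus musculus) for cytotoxicity, read by resazurin assay, with a stated time of 48 h (on this read-out lower numbers stand for stronger inhibition and higher numbers for weaker inhibition), as a limit of the assay
- compound 2 `CCCCn1cc(C(=O)NCc2ccc(OC)c([N+](=O)[O-])c2)c(=O)c2cc(F)c(N3CCC(C(N)=O)CC3)cc21` gives > 100000 nM in this assay as a limit of the assay

Compound 2 stands at the limit of > 100000 nM in this assay, at which 2 of the 2 values shown sit, and has no exact number. Compound 3 `CCCCn1cc(C(=O)NCc2ccc(O)cc2)c(=O)c2cc(F)c(N3CCC(C(N)=O)CC3)cc21` carries 4-hydroxyphenyl in place of 4-methoxy-3-nitrophenyl on a saturated chain carbon bound to an amide-type nitrogen.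

Going by the values given here, no step between measured compounds exists in this assay to set the size of this change. The expectation rests on compound 2 at > 100000 nM as a limit. No change beyond the scatter is expected, and no direction is favoured. The expected change is a number no higher from compound 2 to compound 3 (the limit leaves the size open) on this estimate. Compound 3 is estimated at 100000 nM with an expected range from 45000 nM to 200000 nM in this read-out.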

Compound 3, half-maximal inhibitory concentration: 41600 nM
For compound 3 the middle estimate is 2.4-fold (0.38 log units) above the measured one, outside the stated range (below it).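

In this assay, the group on the saturated chain carbon bound to an amide-type nitrogen proves able to shift the read-out: 4-hydroxyphenyl in place of 4-methoxy-3-nitrophenyl gives an at least 2.4-fold lower number from compound 2 to compound 3 (0.38 log units; beyond the scatter). Going by these compounds alone, compound 3 is the first compound in this set with an exact number rather than a limit, so this position can bring the series into the measurable range. Compound 2 remains a limit, so the step has a lower bound and no fixed size: the limit of > 100000 nM in this assay, at which 2 of the 3 values shown sit.

The compounds shown do not separate the loss of the nitro group from the replacement of methoxy by hydroxy on the phenyl ring. As far as these compounds go, whether an amine, a carboxylic acid or an unsubstituted phenyl at this place gives a number in the same region also stays open.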